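Acetoxy lactones: hydroxy for benzyl on the ring carbon

The source may hold more compounds than are shown below. What is called first, only, known or untested is meant among the compounds shown, and "the series" means these compounds.

Measured so far:
Compound 1 `CC(=O)O[C@@H]1OC(=O)[C@](O)(C(C)=O)[C@@H]1C` gives > 50000 nM in a functional assay on B16 cells (Mus musculus) for cytotoxicity, read by MTT assay; on this read-out lower numbers stand for stronger inhibition and higher numbers for weaker inhibition.
Compound 2 `CC(=O)O[C@@H]1OC(=O)[C@@](Cc2ccccc2)(C(C)=O)[C@@H]1C` gives 45000 nM in this assay.

Among the measured compounds shown here, compound 2 stands as the only numerical result in this assay so far. Compound 1 reaches only a limit of the assay, namely (the limit of > 50000 nM in this assay, at which 1 of the 2 values shown sits). For the measured compounds named here, no step between two measured compounds is known, so the size of a structural change has not been calibrated.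

Compound 3 `CC(=O)O[C@@H]1OC(=O)[C@@](O)(C(C)=O)[C@@H]1C` differs from compound 2 by hydroxy in place of benzyl on a saturated ring carbon. Compound 1 also carries hydroxy in place of benzyl, with the other configuration at that carbon, and in this assay compound 1 gives only a limit. Taken together with the weak value of compound 2, no gain is expected; the step is expected to stay within the scatter or to weaken the compound, with a sizeable chance that only a limit is returned.

The estimate for compound 3 in this assay is 50000 nM, expected between 20000 nM and 120000 nM. The expected step is a 1.1-fold higher number from compound 2 to compound 3 (0.05 log units; within the scatter).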

Compound 3, half-maximal inhibitory concentration: > 50000 nM
Compound 3: no number, only a limit (the forecaster's own chance of this, stated with the estimate: 60%); the middle value lies on the limit itself.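

In this assay compound 3 gives > 50000 nM, a limit of the assay and not a number, and the series now rests largely on that limit: the limit of > 50000 nM in this assay, at which 2 of the 3 values shown sit. Hydroxy in place of benzyl on this saturated ring carbon gives an at least 1.1-fold higher number from compound 2 to compound 3 (0.04 log units; that floor lies within the scatter), so the printed floor shows no gain from the change, while the true size of the step stays unknown. Neither drawn configuration of the hydroxy compounds yields a number in this assay, and the step between them cannot be read, so the data give no reading of how configuration at this carbon acts: the fact that compounds 1 and 3 differ only in the configuration as drawn.

Still open, from the compounds shown here alone, is how far above the limit compounds 1 and 3 lie, and whether the benzyl group of compound 2 contributes to its value, given that the step may or may not exceed the usual scatter. An amine or a longer alkyl chain on this ring carbon would show whether a group other than benzyl also returns a number in this assay.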